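Fluoro for chloro on the fused ring of compound 3

A few compounds are considered here, and "the series" means these few. Any claim that something is new, unique, unknown or untested is made for them only; others in the source may bear on it.

Compound 1 `O=C(O)CN1C(=O)/C(=C/c2nc3ccccc3n2Cc2ccc(F)cc2)SC1=S` gives 1420 nM in a functional assay on HL-60 cells (Homo sapiens) for cytotoxicity, read by MTT assay, with a stated time of 48 h; a lower number here means a stronger inhibitor, a higher number a weaker inhibitor. Compound 2 `O=C(O)CN1C(=O)/C(=C/c2nc3ccccc3n2Cc2ccc(Cl)cc2)SC1=S` gives 2650 nM in this assay, and compound 3 `Cc1ccc(Cn2c(/C=C3\SC(=S)N(CC(=O)O)C3=O)nc3ccc(Cl)cc32)cc1` gives 2840 nM in this assay. The change fluoro in place of chloro on an aromatic carbon made a 1.9-fold lower number from compound 2 to compound 1 (0.27 log units; within the scatter). The difference between the core of compound 2 and the core of compound 3 is not broken down here; their two values lie within the scatter of each other, as do those of compound 1 and compound 3. Compound 4 `Cc1ccc(Cn2c(/C=C3\SC(=S)N(CC(=O)O)C3=O)nc3ccc(F)cc32)cc1` carries the change (fluoro in place of chloro on an aromatic carbon). This is the same kind of change as that from compound 2 to compound 1, not the same: there the place was para to a large group, here it is part of a fused or bridged system of two rings, meta to a fused ring and para to a fused ring. For compound 4 a step of a 1.4-fold lower number from compound 3 to compound 4 (0.15 log units; within the scatter) in this assay is expected. The expectation rests on the step of a 1.9-fold lower number from compound 2 to compound 1 (0.27 log units; within the scatter), which lay within the scatter, while the place differs. Compound 4 is estimated at 2000 nM, expected between 900 nM and 4500 nM.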

Compound 4, half-maximal inhibitory concentration: 1690 nM
The estimate for compound 4 lay 1.2-fold (0.07 log units) above the measured number; the range from low to high includes it.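

In this assay, fluoro in place of chloro on an aromatic carbon gives a 1.7-fold lower number from compound 3 to compound 4 (0.23 log units; within the scatter), and the two steps for this change agree across the two cores: the same change on two cores in this assay, a 1.9-fold lower number (0.27 log units; within the scatter) from compound 2 to compound 1 and a 1.7-fold lower number (0.23 log units; within the scatter) from compound 3 to compound 4, 1.1-fold (0.05 log units) apart, within the scatter of two such steps

The change therefore carries from one core to the other, and from one place to another, with no detectable difference in the size of the step. Each step alone lies within the scatter, so these two pairs do not establish a real difference between fluoro and chloro on either core, and they say nothing about other cores.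

As far as these compounds go, it remains open whether a nitrile or an amine on that aromatic carbon would give a step beyond the scatter. The same question stands for a longer chain carrying the carboxylic acid.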